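From methyl to chloro on an aromatic ring

The source may report more compounds than this note shows. Statements on the series, on what has been measured and on what is new or still open speak of the compounds shown alone.

Measured in a functional assay on MCF7 cells (Homo sapiens) for antiproliferative activity, read by MTT assay, with a stated time of 72 h; a higher number here means a weaker inhibitor, a lower number a stronger inhibitor
Compound 1 `CC1=CC[C@H]2[C@@H]1CC=C(C)[C@@H](CC[C@H]1[C@]3(C)CC[C@H](O)C(C)(C)O[C@H]3CC[C@@]1(C)O)C2(C)C` reads > 50000 nM (a limit)
Compound 2 `CC1=CC[C@H]2[C@@H]1CC=C(C)[C@@H](CC[C@H]1[C@]3(C)CC[C@H](OC(=O)c4ccccc4)C(C)(C)O[C@H]3CC[C@@]1(C)O)C2(C)C` reads 23100 nM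
Compound 3 `CC1=CC[C@H]2[C@@H]1CC=C(C)[C@@H](CC[C@H]1[C@]3(C)CC[C@H](OC(=O)c4ccc(C)cc4)C(C)(C)O[C@H]3CC[C@@]1(C)O)C2(C)C` reads > 50000 nM (a limit)

Compound 3 stands at > 50000 nM as a limit of the assay, not a number. Compound 4 `CC1=CC[C@H]2[C@@H]1CC=C(C)[C@@H](CC[C@H]1[C@]3(C)CC[C@H](OC(=O)c4ccc(Cl)cc4)C(C)(C)O[C@H]3CC[C@@]1(C)O)C2(C)C` carries chloro in place of methyl on an aromatic carbon, para to a large group (chloro in place of methyl on an aromatic carbon). Within the data shown here, two measured steps bear on this. Methyl in place of hydrogen gave an at least 2.1-fold higher number from compound 2 to compound 3 (0.33 log units; beyond the scatter) in this assay and benzoyl in place of hydrogen on an oxygen gave an at least 2.1-fold lower number from compound 1 to compound 2 (0.33 log units; beyond the scatter) there as well. Neither step tests chloro. The nearest true number is that of compound 2 at 23100 nM without the methyl. A modest fall in the number is therefore expected, or no readable step if the limit returns. The estimate amounts to an at least 1.5-fold lower number from compound 3 to compound 4 (0.19 log units; that floor lies within the scatter) as the expected step. For compound 4 the expected value is 32000 nM within an estimated range from 14000 nM to 60000 nM in this test.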

Compound 4, half-maximal inhibitory concentration: 22000 nM
Compound 4: middle estimate off by 1.5-fold (0.16 log units), on the high side; the measured number falls inside the stated range.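

In this assay, chloro in place of methyl on this aromatic carbon, para to a large group, gives an at least 2.2-fold lower number from compound 3 to compound 4 (0.35 log units; beyond the scatter), so chloro does not share the rise in the number seen with methyl. Chloro in place of hydrogen gives a 1.1-fold lower number from compound 2 to compound 4 (0.02 log units; within the scatter), and the whole (4-chlorophenyl)carbonyl group on the oxygen gives an at least 2.2-fold lower number from compound 1 to compound 4 (0.35 log units; beyond the scatter). The first and last of these steps are floors, since one end of each is a limit: the limit of > 50000 nM in this assay, at which 2 of the 4 values shown sit.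

Going by these compounds, whether an amine or a methoxy group on this same carbon would read like compound 4 or like compound 3 remains open.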